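This account rests on a few compounds, and the source may have more. Where it says the series, first, only, none or still open, it means among the compounds named here.

Measured so far:
- compound 1, `C=CC(=O)CCC(=O)OCC(O)COc1ccccc1C`: 2.16
- compound 2, `Cc1ccccc1OCC(O)COC(=O)CCC(=O)/C=C/OC[C@H]1OC(O)[C@H](O)[C@@H](O)[C@@H]1O`: 0.04
- compound 3, `O=C(/C=C/OC[C@H]1OC(O)[C@H](O)[C@@H](O)[C@@H]1O)CCCCC(=O)OCC(O)COc1ccccc1`: 0.59

Compound 1 gives 2.16 in a physicochemical assay for lipophilicity, at pH 7.4; a higher number here means a more lipophilic compound, a lower number a more polar compound. Compound 2 gives 0.04, the lowest of the three numbers; compound 3, with 0.59, is its nearest neighbour and lies beyond the scatter above it, while compound 1 lies furthest above it. None of these pairs differs in one place only, so no single step can be read from them.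

Compound 4, `O=C(/C=C/OC[C@H]1OC(O)[C@H](O)[C@@H](O)[C@@H]1O)CCC(=O)OCC(O)COc1ccc(Cl)cc1`, has not yet been measured. Compared with compound 2 it carries 4-chlorophenyl in place of 2-methylphenyl on an oxygen on a saturated carbon. Among the compounds with values here, no measured pair shows this exchange, so its effect rests on expectation alone: a small shift in this assay, upward if anything, possibly within the scatter. The expected step from a number 0.16 log units higher from compound 2 to compound 4 (within the scatter) puts the estimate for compound 4 at 0.2, between -0.2 and 0.6.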

Compound 4, distribution coefficient: 0.02
Estimate against measurement, compound 4: 0.18 log units above; the measured number falls inside the stated range.
By their numbers in this assay, from the lowest: compounds 4 and 2 (each within the scatter of the next); then compound 3; then compound 1.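

In this assay, within the data shown here, putting 4-chlorophenyl in place of 2-methylphenyl on an oxygen on a saturated carbon gives a number 0.02 log units lower from compound 2 to compound 4 (within the scatter), the first step that can be read at a single place. At this position, then, these two aromatic groups cannot be told apart in this read-out. Nothing shown gives a cause for this. Still open, from the compounds shown here alone, is whether a group of a different kind in the same place, such as an amine or a carboxylic acid, would give a step beyond the scatter.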